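The source may hold more compounds than are shown below. What is called first, only, known or untested is meant among the compounds shown, and "the series" means these compounds.

Compound 1 (`O=C(CCCC1CCN(S(=O)(=O)Nc2ccccc2)CC1)NO`), compound 2 (`CN(c1ccccc1)S(=O)(=O)N1CCC(CCCC(=O)NO)CC1`) and compound 3 (`O=C(CCCC1CCN(S(=O)(=O)Cc2ccccc2)CC1)NO`) are close relatives that share most of their structure. Among the compounds with values here, in a functional assay on HCT-116 cells (Homo sapiens) for inhibition, read by resazurin assay, with a stated time of 5 days (on this read-out higher numbers stand for weaker inhibition of growth and lower numbers for stronger inhibition of growth), compound 1 gives 2000 nM, the only number available so far. For compound 2 the entry reads "not determined" (no result reported), so compound 2 has no place on this scale and cannot serve as a starting value. The structural change leading on to compound 3 is benzyl in place of methyl(phenyl)amino on a sulfonyl sulfur, which amounts to benzyl in place of methyl(phenyl)amino on a sulfonyl sulfur. Within the data shown here, with no measured step to draw on, the only anchor is compound 1 at 2000 nM, and compound 3 is expected to land within the usual scatter of that value in this assay, with no firm direction. For compound 3, the estimated value is 1500 nM, with an expected range from 500 nM to 5000 nM.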

Compound 3, concentration for 50% growth inhibition: 3200 nM
The estimate for compound 3 lay 2.1-fold (0.33 log units) below the measured number; the measured number falls inside the stated range.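

In this assay, benzyl in place of anilino on a sulfonyl sulfur gives a 1.6-fold higher number from compound 1 to compound 3 (0.20 log units; within the scatter), so at this place the two groups cannot be told apart on this read-out. On these data alone, the comparison with compound 2 cannot be read, as compound 2 has no number, and so the effect of methyl(phenyl)amino at this place stays unknown. Nothing available offers an explanation for this result.

As far as these compounds go, it remains open whether a group of a different kind on the sulfonyl sulfur, such as a plain methyl or a longer phenethyl chain, would shift the number beyond the scatter. The same question holds for a phenyl ring carrying a carboxylic acid or an amine.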